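Phenyl for cyclopropyl on the fused five-membered ring

The source may report more compounds than this note shows. Statements on the series, on what has been measured and on what is new or still open speak of the compounds shown alone.

Two members of the series have numbers in a functional assay on COLO 205 cells (Homo sapiens) for antiproliferative activity, read by MTT assay, with a stated time of 68 h; on this read-out lower numbers stand for stronger inhibition and higher numbers for weaker inhibition. Compound 1 `CCOc1n[nH]c2ncc(C#Cc3c(F)ccc(NS(=O)(=O)c4cccnc4)c3F)cc12` gives 1980 nM. Compound 2 `O=S(=O)(Nc1ccc(F)c(C#Cc2cnc3[nH]nc(C4CC4)c3c2)c1F)c1cccnc1` gives 61 nM. Among the measured compounds shown here, the one step between them, a 32-fold lower number from compound 1 to compound 2 (1.51 log units; beyond the scatter), is large and beyond the scatter. For the measured compounds named here, compound 2 therefore stands lowest of the two numbers, with compound 1 as its only neighbour, at the higher end of that step.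

Compound 3 `O=S(=O)(Nc1ccc(F)c(C#Cc2cnc3[nH]nc(-c4ccccc4)c3c2)c1F)c1cccnc1` differs from compound 2 by phenyl in place of cyclopropyl on an aromatic carbon. Going by the values given here, no measured step touches this change; the only step known, from ethoxy to cyclopropyl at the same place, says nothing about a phenyl there. The cyclopropyl is kept as the reference, and a step of modest size in either direction in this assay cannot be ruled out. Compound 3 is expected at about 120 nM, that is a step of a 2.0-fold higher number from compound 2 to compound 3 (0.29 log units; within the scatter), with a range from 30 nM to 500 nM.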

Compound 3, half-maximal inhibitory concentration: 200 nM
Beside the measured number, compound 3's estimate is 1.7-fold (0.22 log units) below it; measured number inside the range.
By their numbers in this assay, from the lowest: compound 2; then compound 3; then compound 1.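

In this assay, this aromatic carbon of the five-membered aromatic ring still gives a number well under that of the ethoxy compound when it carries a six-membered aromatic ring: phenyl in place of ethoxy gives a 9.9-fold lower number from compound 1 to compound 3 (1.00 log units; beyond the scatter). Cyclopropyl nevertheless keeps its place at the low end, as phenyl in place of cyclopropyl gives a 3.3-fold higher number from compound 2 to compound 3 (0.52 log units; beyond the scatter), so the two ring groups are separated and the order at this place runs cyclopropyl, phenyl, ethoxy. Nothing at hand explains this order.

Among the compounds shown here, with only three groups at this place, the effect of ring size cannot be separated from that of an aromatic ring. A cyclobutyl or pyridyl ring would help to make that separation, while an amine or a longer alkyl chain would test whether the order extends beyond these groups.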